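The source may hold more compounds than are shown below. What is called first, only, known or untested is meant among the compounds shown, and "the series" means these compounds.

Measured so far in a functional assay on MCF7 cells (Homo sapiens) for antiproliferative activity, read by sulforhodamine B assay, with a stated time of 48 h; on this read-out lower numbers stand for stronger inhibition of growth and higher numbers for weaker inhibition of growth:
compound 1 `O=C(NCc1cn(Cc2ccc(Cl)cc2)nn1)c1cn(-c2ccccc2)nc1-c1ccc(F)cc1` gives 130 nM
compound 2 `O=C(NCc1cn(Cc2ccc(F)cc2)nn1)c1cn(-c2ccccc2)nc1-c1ccc(Cl)cc1` gives 570 nM

Compound 2 holds the higher of the two numbers in this assay; compound 1 sits lower, beyond the scatter. Compound 3 `O=C(NCc1cn(Cc2ccc(Cl)cc2)nn1)c1cn(-c2ccccc2)nc1-c1ccc(Cl)cc1` has not been measured. It differs from compound 2 by chloro in place of fluoro on an aromatic carbon, so 4-fluorobenzyl becomes 4-chlorobenzyl with the rest unchanged. Among the compounds with values here, no step between measured compounds isolates this change. Compound 1, which also carries the 4-chlorobenzyl, gives 130 nM, and on that basis a modest move toward stronger inhibition is expected. The expected step is a 2.3-fold lower number from compound 2 to compound 3 (0.36 log units; beyond the scatter). Compound 3 is estimated at 250 nM, within 90 nM to 700 nM.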

Compound 3, concentration for 50% growth inhibition: 28800 nM
Estimate against measurement, compound 3: 120-fold (2.06 log units) below; the measured number lies above the stated range.
By their numbers in this assay, from the lowest: compound 1; then compound 2; then compound 3.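

In this assay the change of 4-fluorobenzyl to 4-chlorobenzyl gives a 51-fold higher number from compound 2 to compound 3 (1.70 log units; beyond the scatter) and the change of 4-fluorophenyl to 4-chlorophenyl gives a 220-fold higher number from compound 1 to compound 3 (2.35 log units; beyond the scatter) with the rest unchanged. Within the data shown here, both aromatic positions therefore respond strongly to one halogen exchange, and compound 3, the only compound with chloro on both rings, is the weakest of the three. A fluoro on either ring goes with a far lower number than chloro on both.

From the compounds shown here alone, whether fluoro on both rings would lower the number further stays open, as does how a methoxy group or an amine would read at either position. Nothing available explains these steps.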